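Compound 3 and a 4-methoxyphenyl change

A few compounds are considered here, and "the series" means these few. Any claim that something is new, unique, unknown or untested is made for them only; others in the source may bear on it.

Among the compounds with values here, in a functional assay on MOLT-4 cells (Homo sapiens) for antiproliferative activity (on this read-out lower numbers stand for stronger inhibition and higher numbers for weaker inhibition), compound 3 `COc1cc(C(=O)c2sc(-c3ccccc3Cl)cc2N)cc(OC)c1OC` has the lowest number so far at 17 nM, and compound 2 `COc1cc(C(=O)c2sc(-c3ccc(Br)cc3)cc2N)cc(OC)c1OC` gives 92 nM. Compound 1 `COc1cc(C(=O)c2sc(-c3ccc(-c4ccccc4)cc3)cc2N)cc(OC)c1OC` reaches only a limit, > 10000 nM. Compound 4 `COc1ccc(-c2cc(N)c(C(=O)c3cc(OC)c(OC)c(OC)c3)s2)cc1` is still unmeasured: 4-methoxyphenyl in place of 2-chlorophenyl on an aromatic carbon, with 4-methoxyphenyl in place of 2-chlorophenyl on an aromatic carbon. Two measured steps changed the group at this same place: the large at least 100-fold lower number from compound 1 to compound 2 (2.03 log units; beyond the scatter) and the modest 5.4-fold lower number from compound 2 to compound 3 (0.73 log units; beyond the scatter). The entering 4-methoxyphenyl resembles the 4-bromophenyl of compound 2 at 92 nM, so a modest rise in the number is expected in this assay, beyond the scatter. The expected change is a 2.6-fold higher number from compound 3 to compound 4 (0.42 log units; beyond the scatter). For compound 4 the estimate is 45 nM, with an expected range of 12 nM to 180 nM.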

Compound 4, half-maximal inhibitory concentration: 18 nM
The estimate for compound 4 lay 2.5-fold (0.40 log units) above the measured number; the range from low to high includes it.
By their numbers in this assay, from the lowest: compounds 3 and 4 (each within the scatter of the next); then compound 2. At a limit, above all of these: compound 1.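

In this assay, 2-chlorophenyl and 4-methoxyphenyl cannot be told apart at this place, with a 1.1-fold higher number from compound 3 to compound 4 (0.02 log units; within the scatter). Methoxy in place of bromo gives a 5.1-fold lower number from compound 2 to compound 4 (0.71 log units; beyond the scatter), so a 4-substituted phenyl does not by itself set the number in this series of compounds. Against compound 1, whose value is a limit, the step is an at least 550-fold lower number from compound 1 to compound 4 (2.74 log units; beyond the scatter), and it can be read only against that limit: the limit of > 10000 nM in this assay, at which 1 of the 4 values shown sits.

The compounds shown leave open how a hydroxyl or an amine in place of methoxy would read, and whether a longer chain such as ethoxy would hold the number of compound 4.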